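From a Bromophenol to a Fused Bicycle on a Shared Core

A few compounds are considered here, and "the series" means these few. Any claim that something is new, unique, unknown or untested is made for them only; others in the source may bear on it.

Compound 1 `CCOC(=O)C1=C(Nc2ccccc2)S/C(=C\c2ccc(Br)c(O)c2)C1=O` stands as the lower of the two measured numbers in a functional assay on A549 cells (Homo sapiens) for inhibition, read by MTT assay, with a stated time of 72 h, tested at 10 uM (on this read-out higher numbers stand for more inhibition at the one concentration tested (going by the name of the read-out) and lower numbers for less inhibition), where compound 1 gives 13.6%. Compound 3 `CCOC(=O)C1=C(Nc2ccc(CC)cc2)S/C(=C\c2ccc[nH]2)C1=O` gives 17.5% in this assay, a value that sits within the scatter of compound 1. Compound 2 `CCOC(=O)C1=C(Nc2ccccc2)S/C(=C\c2ccccc2C(F)(F)F)C1=O` gives < 10% in this assay; this is a limit of the assay and not a number, namely (the limit of < 10% in this assay, at which 1 of the 3 values shown sits), so no number is known for it. Compound 4 `CCOC(=O)C1=C(Nc2ccccc2)S/C(=C\c2cc3cccnc3[nH]2)C1=O` has not been tested. It differs from compound 1 by a group of 9 heavy atoms (7 carbon, 2 nitrogen; one five-membered aromatic ring with 1 hetero atom, one six-membered aromatic ring with 1 hetero atom) in place of a group of 8 heavy atoms (6 carbon, 1 oxygen, 1 bromine; one six-membered aromatic ring of carbon only), on a double-bonded chain carbon bound to a double-bonded ring carbon. Among the measured compounds shown here, no measured pair of compounds shares this kind of change, so its effect is unknown. Given the narrow spread among the measured compounds, compound 4 is expected to stay near compound 1, with an estimated step of a number 1.4 percentage points higher from compound 1 to compound 4 (within the scatter) of no size beyond the scatter. The estimated value for compound 4 is 15%, expected to lie between 5% and 35%.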

Compound 4, a percentage reported as inhibition, at one concentration (the size of the read-out at that concentration, not a potency): 16.7%
Compound 4: middle estimate off by 1.7 percentage points, on the low side; the range from low to high includes it.
By their numbers in this assay, from the lowest: compounds 1, 4 and 3 (each within the scatter of the next). At a limit, below all of these: compound 2.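

In this assay, putting the new two-ring group in place of 4-bromo-3-hydroxyphenyl, on a double-bonded chain carbon bound to a double-bonded ring carbon, gives a number 3.1 percentage points higher from compound 1 to compound 4 (within the scatter). This position therefore accepts a group without bromine and with ring nitrogens, and the number does not move beyond the scatter. Nothing measured here gives a reason for this step. From the compounds shown here alone, it remains open whether any group at this place can move the number beyond the scatter. A basic amine such as a dimethylaminomethyl group or a carboxylic acid on the ring at this place would test that.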